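Tetrabromobenzotriazole hydroxyalkyl series: antiproliferative notes

A few compounds are considered here, and "the series" means these few. Any claim that something is new, unique, unknown or untested is made for them only; others in the source may bear on it.

Measured so far:
compound 1 `OCC(O)Cn1nc2c(Br)c(Br)c(Br)c(Br)c2n1` gives 145% in a functional assay on MCF7 cells (Homo sapiens) for antiproliferative activity, read by MTT assay, with a stated time of 24 h, tested at 12.5 uM; a higher number here means a weaker effect of the compound at the concentration tested, a lower number a stronger effect.
compound 2 `OC(CCn1nc2c(Br)c(Br)c(Br)c(Br)c2n1)c1cccc(Cl)c1` gives 97%.

Compound 2 stands lowest of the two numbers; its nearest neighbour is compound 1, whose number is higher by a gap beyond the usual scatter. Compound 3 `CC(O)CCn1nc2c(Br)c(Br)c(Br)c(Br)c2n1` is not yet measured. It differs from compound 2 in one place: methyl in place of 3-chlorophenyl on a saturated chain carbon bound to an oxygen on a saturated carbon and a saturated chain carbon. With the 3-chlorophenyl gone and only a methyl remaining, compound 3 sits closer in build to compound 1, so the step is expected to run upward, toward a weaker effect, by an amount beyond the scatter, as a number 28 percentage points higher from compound 2 to compound 3 (beyond the scatter). For compound 3 the estimate is 125%, expected to fall between 95% and 155%.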

Compound 3, a percentage reported as activity, at one concentration (the size of the read-out at that concentration, not a potency): 99%
The estimate for compound 3 lay 26 percentage points above the measured number; measured number inside the range.
By their numbers in this assay, from the lowest: compounds 2 and 3 (each within the scatter of the next); then compound 1.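

In this assay, exchanging the 3-chlorophenyl for methyl on this saturated chain carbon changes nothing that can be told from the scatter, a number 2 percentage points higher from compound 2 to compound 3 (within the scatter), so the aromatic ring is not needed to hold the number here. The large change lies elsewhere: 2-hydroxypropyl in place of 1,2-dihydroxyethyl on a saturated chain carbon bound to an aromatic nitrogen gives a number 46 percentage points lower from compound 1 to compound 3 (beyond the scatter). No data at hand speak to the cause of either step. On these data alone, whether an amine or a carboxylic acid in place of the methyl would shift the number remains open, as does the effect of a longer chain.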